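This account rests on a few compounds, and the source may have more. Where it says the series, first, only, none or still open, it means among the compounds named here.

Working notes on the series. In a functional assay on PC-12 cells (Rattus norvegicus) for cytotoxicity, read by MTT assay, with stated times of 2 h and 24 h, tested at 10 uM (a higher number here means a stronger effect of the compound at the concentration tested, a lower number a weaker effect), compound 1 `Cc1ccc(-n2nc(-c3ccc(C(F)(F)F)cc3O)nc2-c2ccccc2O)cc1` gives 102% and compound 2 `Oc1cc(C(F)(F)F)ccc1-c1nc(-c2ccccc2O)n(-c2ccc(Cl)cc2)n1` gives 96.1%. Among the measured compounds shown here, the only measured step, chloro in place of methyl on an aromatic carbon, a number 5.9 percentage points lower from compound 1 to compound 2 (within the scatter). Compound 2 therefore stands alongside compound 1, the two numbers lying within the scatter of each other. Compound 3 `Oc1cc(C(F)(F)F)ccc1-c1nc(-c2ccccc2O)n(-c2ccccc2Cl)n1` differs from compound 2 by 2-chlorophenyl in place of 4-chlorophenyl on an aromatic nitrogen. For the measured compounds named here, no measured step shifts the chlorine within the same ring, so only the step from compound 1 to compound 2 bears on it, and that step stayed within the scatter. No step beyond the scatter is expected for compound 3 in this assay. The estimated step is a number 0.1 percentage points lower from compound 2 to compound 3 (within the scatter). Compound 3 is estimated at 96%, within 80% to 110%.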

Compound 3, a percentage reported as activity, at one concentration (the size of the read-out at that concentration, not a potency): 102%
Beside the measured number, compound 3's estimate is 6 percentage points below it, within the range that was stated.
By their numbers in this assay, from the lowest: compounds 2, 1 and 3 (each within the scatter of the next).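

Among the compounds shown here, compound 3 is the first change at this aromatic nitrogen that keeps the chlorine and alters only its place on the phenyl ring: in this assay, 2-chlorophenyl in place of 4-chlorophenyl gives a number 5.9 percentage points higher from compound 2 to compound 3 (within the scatter). 2-Chlorophenyl in place of 4-methylphenyl gives no change at the digits printed from compound 1 to compound 3 (within the scatter), so across these three compounds neither the place of the chlorine nor chloro versus methyl separates the numbers. No accompanying measurement bears on these results.

From the compounds shown here alone, whether an amine or a carboxylic acid on that phenyl ring would give a step beyond the scatter stays open.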